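Saturating the oleyl chain of the diisopropylphenyl urea

The source may report more compounds than this note shows. Statements on the series, on what has been measured and on what is new or still open speak of the compounds shown alone.

Compound 2 `CCCCCCCC/C=C\CCCCCCCCNC(=O)Nc1c(C(C)C)cccc1C(C)C` gives 28 nM in an assay on microsomes from intestinal mucosa for inhibition of acyl-CoA:cholesterol acyltransferase (Oryctolagus cuniculus); on this read-out lower numbers stand for stronger inhibition and higher numbers for weaker inhibition. Of the two numbers in hand compound 2 carries the lower one; compound 1 `CCCCCCCC/C=C\CCCCCCCCNC(=O)Nc1c(CC)cccc1C(C)C` stands nearest with 37 nM, and the step of a 1.3-fold lower number from compound 1 to compound 2 (0.12 log units; within the scatter) puts that gap within the scatter. Compound 3 `CCCCCCCCCCCCCCCCCCNC(=O)Nc1c(C(C)C)cccc1C(C)C` differs from compound 2 by decyl in place of dec-1-en-1-yl on a saturated chain carbon, eight bonds along the chain from an amide-type nitrogen. Within the data shown here, the single measured step alters the aromatic substituent, not the chain, so no step in hand bears on this change, and in this assay nothing beyond the scatter is expected from it. Compound 3 is estimated at 35 nM, range 12 nM to 100 nM. The expected step is a 1.3-fold higher number from compound 2 to compound 3 (0.10 log units; within the scatter).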

Compound 3, half-maximal inhibitory concentration: 48 nM
The estimate for compound 3 lay 1.4-fold (0.14 log units) below the measured number, within the range that was stated.
By their numbers in this assay, from the lowest: compounds 2, 1 and 3 (each within the scatter of the next).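

Among these compounds, this is the first change to the chain rather than the aromatic substituents: decyl in place of dec-1-en-1-yl gives a 1.7-fold higher number from compound 2 to compound 3 (0.23 log units; within the scatter) in this assay so the number of compound 3 stays within the scatter of compound 2 without the chain's double bond. At this place, eight bonds along the chain from an amide-type nitrogen, that double bond can therefore be lost without a change beyond the scatter. No supporting data bear on this result.

The compounds shown leave open how a shorter or a longer chain would read in this assay. Also open, as far as these compounds go, is whether an amine or a carboxylic acid carried on the chain would be tolerated.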